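Chloro for hydrogen on the shared core of compound 1

A few compounds are considered here, and "the series" means these few. Any claim that something is new, unique, unknown or untested is made for them only; others in the source may bear on it.

Measured so far:
compound 1 `ClCc1cccc(Cn2cnc3ncnc(Cl)c32)c1` — 46800 nM
compound 2 `ClCc1ccc(Cn2cnc3nc(Cl)nc(Cl)c32)cc1` — "not determined" (no result reported)

Among the compounds with values here, compound 1 carries the only number in this set. In a functional assay on OVCAR-4 cells (Homo sapiens) for cytotoxicity, read by sulforhodamine B assay, with a stated time of 48 h (on this read-out higher numbers stand for lower toxicity in this test and lower numbers for higher toxicity in this test), compound 1 gives 46800 nM, so it is the single point of reference; compound 2 adds a structure but no figure, and nothing can be said of where it stands relative to compound 1.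

Compound 3 `ClCc1cccc(Cn2cnc3nc(Cl)nc(Cl)c32)c1` is the next candidate. It differs from compound 1 in one place: chloro in place of hydrogen on an aromatic carbon. Within the data shown here, no pair of measured compounds spans a change of this kind, so there is no measured step to lean on.

With nothing else to anchor it, the expectation for compound 3 is a step from compound 1 that stays near the usual scatter, with at most a modest shift toward greater toxicity, expressed as a 1.3-fold lower number from compound 1 to compound 3 (0.13 log units; within the scatter). The estimate for compound 3 in this assay is therefore 35000 nM, expected to lie between 10000 nM and 120000 nM.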

Compound 3, concentration lethal to 50% of the cells: 5370 nM
The estimate for compound 3 lay 6.5-fold (0.81 log units) above the measured number; the whole stated range lies above it.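

In this assay, within the data shown here, chloro in place of hydrogen on the aromatic carbon between two ring nitrogen atoms gives an 8.7-fold lower number from compound 1 to compound 3 (0.94 log units; beyond the scatter), the first step to be read and one that lies beyond the scatter. This carbon of the shared core is therefore a place where the read-out responds to a single added heavy atom, and the direction is toward higher toxicity in this test. Nothing at hand bears on the reason for this shift, so the step stands as an observation only.

On these data alone, with one step at this carbon, it remains open whether the shift is particular to chloro or would also appear with an amine, a methoxy group or a longer chain in the same place. As far as these compounds go, the step involving compound 2 cannot be read, so it also remains open whether the effect of the chloro depends on where the chloromethyl group sits on the other ring.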